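The source may report more compounds than this note shows. Statements on the series, on what has been measured and on what is new or still open speak of the compounds shown alone.

Of the compounds shown here, two built on one shared core have been measured in a functional assay on MCF7 cells (Homo sapiens) for cytotoxicity, read by MTT assay, with a stated time of 48 h; on this read-out lower numbers stand for stronger inhibition and higher numbers for weaker inhibition. Compound 1, `Nc1cc(-c2cnc3[nH]cc(-c4ccncc4)c3c2)ccc1Cl`, gives 12000 nM in this assay. Compound 2, `Cc1ccc(-c2cnc3[nH]cc(-c4ccncc4)c3c2)cc1N`, gives 2800 nM in this assay. The single step between them, a 4.3-fold lower number from compound 1 to compound 2 (0.63 log units; beyond the scatter), is a modest one, and it leaves compound 2 with the lowest of the two numbers shown, its nearest neighbour being compound 1 with the higher number.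

Compound 3, `COc1ccc(-c2cnc3[nH]cc(-c4ccncc4)c3c2)cc1N`, has not yet been measured. It differs from compound 2 by methoxy in place of methyl on an aromatic carbon, the new group sitting on an aromatic carbon of a six-membered aromatic ring of carbon only, ortho to an amino group and para to a large group. Among the measured compounds shown here, no measured step covers a swap of methyl for methoxy. For the measured compounds named here, the only step available, a 4.3-fold lower number from compound 1 to compound 2 (0.63 log units; beyond the scatter), concerns a different replacement at that place and so gives no direct guide. With nothing pointing one way or the other, the expected step is a 1.1-fold lower number from compound 2 to compound 3 (0.05 log units; within the scatter), which is not beyond the scatter. Compound 3 is therefore estimated at 2500 nM, with a range from 800 nM to 8000 nM.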

Compound 3, half-maximal inhibitory concentration: 8700 nM
The estimate for compound 3 lay 3.5-fold (0.54 log units) below the measured number; the whole stated range lies below it.
By their numbers in this assay, from the lowest: compound 2; then compounds 3 and 1 (each within the scatter of the next).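

In this assay, the aromatic carbon ortho to an amino group and para to a large group proves sensitive to more than the swap of chloro for methyl: the change from methyl to methoxy brings a 3.1-fold higher number from compound 2 to compound 3 (0.49 log units; beyond the scatter) and so gives up the lower number held by compound 2. The direct comparison of methoxy with chloro, a 1.4-fold lower number from compound 1 to compound 3 (0.14 log units; within the scatter) for that step, does not separate these two groups, so of the three groups shown at this place, only the methyl of compound 2 stands apart. The data shown offer no measured property or other outside information that could explain why the methyl group stands apart.

The compounds shown leave open whether the low number is particular to methyl or would also appear with another small carbon group such as ethyl, and whether a hydroxyl group or a single fluorine atom at this place would fall with methyl or with methoxy and chloro. They also leave open whether the same order of these three groups would hold if the amino group on this ring were replaced by another group, such as an amide.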